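Working notes: benzyloxy to allyloxy

A few compounds are considered here, and "the series" means these few. Any claim that something is new, unique, unknown or untested is made for them only; others in the source may bear on it.

Measured in a functional assay on U-87MG ATCC cells for antiproliferative activity against U-87 MG (Homo sapiens), read by MTT assay; on this read-out higher numbers stand for weaker inhibition and lower numbers for stronger inhibition:
compound 1 `Cc1cc(=O)c(O)c(Cc2ccc(C(F)(F)F)cc2)o1`: > 50000 nM (a limit)
compound 2 `Cc1cc(=O)c(O)c(Cc2ccc(OCc3ccccc3)cc2)o1`: > 50000 nM (a limit)
compound 3 `Cc1cc(=O)c(O)c(C(c2ccc(OCc3ccccc3)cc2)c2oc(C)cc(=O)c2O)o1`: 4600 nM

Among the measured compounds shown here, compound 3, at 4600 nM, holds the only true number so far. Compound 1 and compound 2 stand at the limit of > 50000 nM in this assay, at which 2 of the 3 values shown sit.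

Compound 4 `C=CCOc1ccc(C(c2oc(C)cc(=O)c2O)c2oc(C)cc(=O)c2O)cc1` differs from compound 3 by vinyl in place of phenyl on a saturated chain carbon bound to an oxygen on an aromatic ring, which reads as benzyloxy to allyloxy. Compound 4 keeps the group whose addition came with an at least 10-fold lower number from compound 2 to compound 3 (1.03 log units; beyond the scatter). The other measured step, a step that the two limits leave unreadable from compound 1 to compound 2, offers no size to carry over. In this assay the expected outcome is therefore no step beyond the scatter, with a slight drift to a higher number, estimated as a 1.5-fold higher number from compound 3 to compound 4 (0.18 log units; within the scatter). For compound 4 the estimate is 7000 nM, with an expected range of 2500 nM to 25000 nM.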

Compound 4, half-maximal inhibitory concentration: 30900 nM
Beside the measured number, compound 4's estimate is 4.4-fold (0.64 log units) below it; measured number outside the range, above it.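

In this assay, among the compounds shown here, vinyl in place of phenyl on the saturated chain carbon bound to an oxygen on an aromatic ring gives a 6.7-fold higher number from compound 3 to compound 4 (0.83 log units; beyond the scatter), the first readable step at this position, so the number here depends on more than the added group kept from compound 3. Compound 4 still gives a true number, whereas compound 1 and compound 2 remain limits, not numbers: the limit of > 50000 nM in this assay, at which 2 of the 4 values shown sit.

On these data alone, whether the phenyl ring itself matters, or the vinyl double bond, stays open. A propyl chain, an amine or a carboxylic acid at this place could separate the two.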